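The compounds below may be only part of what the source reports. "The series", "measured", "known", "first", "only" and "open" are said of these compounds alone.

Measured so far:
compound 1 `O=C(CCCCC(S)CCS)Nc1ccccn1` — in a functional assay on HO8910 cells (Homo sapiens) for inhibition, read by MTT assay, with a stated time of 24 h, tested at 100 ug/mL (on this read-out higher numbers stand for more inhibition of growth at the one concentration tested and lower numbers for less inhibition of growth), compound 1 gives 14.2%
compound 2 `O=C(CCCCC(S)CCS)Nc1ccc(Cl)cn1` — in this assay compound 2 gives 71.2%
compound 3 `CC(=O)SCCC(CCCCC(=O)Nc1ccccc1)SC(C)=O` — in this assay compound 3 gives 22.3%

Compound 1 and compound 2 share one core and differ in a single place: chloro in place of hydrogen on an aromatic carbon. This change made a step of a number 57 percentage points higher from compound 1 to compound 2 (beyond the scatter). Compound 3 has a different core; how the two cores differ is not broken down here. The numbers of compound 3 and compound 1 lie within the usual scatter of each other, so nothing can be said about their order.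

Compound 4 `CC(=O)SCCC(CCCCC(=O)Nc1ccccc1Cl)SC(C)=O` has not yet been measured. It differs from compound 3 by chloro in place of hydrogen on an aromatic carbon. This is the same kind of change as that from compound 1 to compound 2, but the place is not the same: in compound 2 the chloro sits on a six-membered aromatic ring with one nitrogen, two atoms from the ring nitrogen and para to a large group, whereas in compound 4 it sits on a six-membered aromatic ring of carbon only, ortho to a large group.

Because the earlier change gave a number 57 percentage points higher from compound 1 to compound 2 (beyond the scatter), a rise is expected from compound 3 to compound 4, though a smaller and less certain one, estimated at a number 22.7 percentage points higher from compound 3 to compound 4 (beyond the scatter). For compound 4 in this assay the estimate is 45%, expected to fall between 15% and 80%.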

Compound 4, percent growth inhibition at one concentration: "not active" (no number reported)
For compound 4 the study gives words and no number, so the estimate cannot be set against anything.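

In this assay, going by these compounds alone, compound 4 is reported only as not active, with no number, and no step from compound 3 to compound 4 can be read. These compounds leave open how chloro in place of hydrogen, ortho to a large group, changes growth inhibition on this core. Nothing shown bears on this result.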